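The compounds below may be only part of what the source reports. "The series", "measured", "known", "first", "only" and "open" are said of these compounds alone.

Measured compounds:
- compound 1, `CNC(=O)[C@@H](c1ccccc1)N1CCn2c(CC3CC3)nc(Cl)c2[C@@H]1CCc1ccc(C(F)(F)F)cc1`, in a functional assay on CHO cells for antagonist activity at Orexin/Hypocretin receptor type 1 (Homo sapiens), read by FLIPR and calcium flux (on this read-out higher numbers stand for weaker inhibition and lower numbers for stronger inhibition), compound 1 gives 1430 nM
- compound 2, `CCc1nc(C(C)C)c2n1CCN([C@@H](C(=O)NC)c1ccccc1)C2CCc1ccc(C(F)(F)F)cc1`, compound 2 gives 10000 nM
- compound 3, `CCc1nc(I)c2n1CCN([C@@H](C(=O)NC)c1ccccc1)C2CCc1ccc(C(F)(F)F)cc1`, compound 3 gives 717 nM

Compound 3 has the lowest of the three numbers in this assay. Among the measured compounds shown here, its gap to compound 1 lies within the scatter, so the two cannot be ordered; its gap to compound 2 is large, seen in the single-point step a 14-fold lower number from compound 2 to compound 3 (1.14 log units; beyond the scatter), which is the only step measured at this position.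

Compound 4, `CCc1nc(C(=O)N(C)C)c2n1CCN([C@@H](C(=O)NC)c1ccccc1)C2CCc1ccc(C(F)(F)F)cc1`, is not yet measured. It differs from compound 3 in one place: dimethylcarbamoyl in place of iodo on an aromatic carbon. For the measured compounds named here, the one step that bears on this change is the one from compound 2 to compound 3, where a non-halogen group gave way to a halogen and the number fell sharply. Compound 4 goes the other way, from a halogen to a non-halogen group, though to a different one than isopropyl, so the size of the isopropyl step is only a rough guide. Compound 4 is therefore expected to give a higher number than compound 3, with the step of a 7.0-fold higher number from compound 3 to compound 4 (0.84 log units; beyond the scatter) expected. The estimate for compound 4 in this assay is 5000 nM, within a range from 1500 nM to 15000 nM.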

Compound 4, half-maximal inhibitory concentration: 344 nM
Compound 4: middle estimate off by 15-fold (1.16 log units), on the high side; measured number below the stated range.
By their numbers in this assay, from the lowest: compound 4; then compounds 3 and 1 (each within the scatter of the next); then compound 2.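

At this aromatic carbon in this assay, dimethylcarbamoyl, with its five heavy atoms and one hydrogen-bond acceptor, is tolerated at least as well as iodo: the swap gives a 2.1-fold lower number from compound 3 to compound 4 (0.32 log units; beyond the scatter) as a modest step. Measured against isopropyl, the same group gives a 29-fold lower number from compound 2 to compound 4 (1.46 log units; beyond the scatter) as a large step, so the position responds strongly to which group it carries. The step from isopropyl to iodo alone could have been read as favouring a halogen here, but compound 4 has no halogen at this carbon and still has the lowest number of the three compounds that differ only at this position, so a halogen is not needed and the two non-halogen groups sit at opposite ends of the series.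

No measurement shown accounts for this order of the three groups.
From the compounds shown here alone, it remains open whether the lower number goes with the carbonyl or with the dimethylamino part of the group, and a primary carboxamide, a carboxylic acid or a simple amine at this carbon would bear on that.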